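Chloro for methyl at the biaryl end of the series

The source may hold more compounds than are shown below. What is called first, only, known or untested is meant among the compounds shown, and "the series" means these compounds.

Measured so far:
compound 1, `CCCS(=O)(=O)Nc1ccc(F)c(C(=O)c2n[nH]c3ncc(-c4ccc(C(C)C)cc4)cc23)c1F`: 17%
compound 2, `CCCS(=O)(=O)Nc1ccc(F)c(C(=O)c2n[nH]c3ncc(-c4ccc(S(N)(=O)=O)cc4C)cc23)c1F`: 3.1%

Both compounds share one core and differ only in the aryl group carried on an aromatic carbon. In an assay for binding affinity to dual specificity mitogen-activated protein kinase kinase 4 (Homo sapiens), read by KINOMEscan, tested at 100 nM (a higher number here means a weaker effect of the compound at the concentration tested, a lower number a stronger effect), compound 1 gives 17%, while compound 2 gives 3.1%. Among the measured compounds shown here, the one step that connects them, a number 13.9 percentage points lower from compound 1 to compound 2 (beyond the scatter), goes with 2-methyl-4-sulfamoylphenyl in place of 4-isopropylphenyl. Compound 2 thus stands lowest of the two numbers, with compound 1 the nearest and higher by a margin beyond the scatter.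

Compound 3, `CCCS(=O)(=O)Nc1ccc(F)c(C(=O)c2n[nH]c3ncc(-c4ccc(S(N)(=O)=O)cc4Cl)cc23)c1F`, has not yet been measured. It differs from compound 2 by chloro in place of methyl on an aromatic carbon; cut one bond further out, this reads 2-methyl-4-sulfamoylphenyl to 2-chloro-4-sulfamoylphenyl. For the measured compounds named here, no measured step exchanges a methyl for a chloro, so the only bearing step is a number 13.9 percentage points lower from compound 1 to compound 2 (beyond the scatter), which concerns a far larger exchange of the whole aryl group. A single heavy atom swapped for another of the same count gives no ground to expect a step beyond the scatter in this assay. Compound 3 is therefore estimated at 4%, within 1% to 15%, an expected step of a number 0.9 percentage points higher from compound 2 to compound 3 (within the scatter).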

Compound 3, a percentage reported as activity, at one concentration (the size of the read-out at that concentration, not a potency): 3.4%
Beside the measured number, compound 3's estimate is 0.6 percentage points above it; measured number inside the range.
By their numbers in this assay, from the lowest: compounds 2 and 3 (each within the scatter of the next); then compound 1.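

In this assay, chloro in place of methyl on an aromatic carbon, ortho to a large group and meta to a sulfamoyl group, gives a number 0.3 percentage points higher from compound 2 to compound 3 (within the scatter), so this exchange of one heavy atom for another does not separate the two compounds at the tested concentration. The exchange of the whole aryl group now has a second reading, a number 13.6 percentage points lower from compound 1 to compound 3 (beyond the scatter), which stands with a number 13.9 percentage points lower from compound 1 to compound 2 (beyond the scatter) and shows that the lower number does not depend on methyl alone, since it holds with either group at this place. No measurement here bears on why either substituent behaves as it does.

Going by these compounds, the read-out comes from a single concentration, so any difference between compound 2 and compound 3 in the strength of their effect at other concentrations remains unresolved, and it is open whether a hydrogen, methoxy or trifluoromethyl at this place would also leave the number unchanged. Also open, on these data alone, is how the step from compound 1 divides between the sulfamoyl group and the group at this place, and whether a carboxylic acid or an amine could stand in for the sulfamoyl group.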